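This account rests on a few compounds, and the source may have more. Where it says the series, first, only, none or still open, it means among the compounds named here.

Compound 1 `Cc1nc(-c2ccccc2)sc1C(=O)CSc1nc(N)c(C#N)c(-c2ccccc2)n1` is the reference point of this small series. In a functional assay on U-87MG ATCC cells for antiproliferative activity against U-87 MG (Homo sapiens), read by MTT assay, with a stated time of 48 h, tested at 5 uM (on this read-out higher numbers stand for a weaker effect at the one concentration tested and lower numbers for a stronger effect), compound 1 gives 103%. Compound 2 `Cc1nc(-c2ccc(Cl)cc2)sc1C(=O)CSc1nc(N)c(C#N)c(-c2ccccc2)n1` carries the change chloro in place of hydrogen on an aromatic carbon on the same core, and in this assay compound 2 gives 71.1%. Within the data shown here, the step of a number 31.9 percentage points lower from compound 1 to compound 2 (beyond the scatter) is the only measured step in the set, and it is large.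

Compound 3 `COc1ccc(-c2nc(C)c(C(=O)CSc3nc(-c4ccccc4)c(C#N)c(=O)[nH]3)s2)cc1` is built on a different core; how its core differs from that of compound 1 is not broken down here. In this assay compound 3 gives 99%, which lies within the usual scatter of the number of compound 1, so no order between compound 3 and compound 1 can be stated, while the number of compound 2 stands clearly lower than both.

Compound 4 `COc1ccc(-c2nc(C)c(C(=O)CSc3nc(-c4cccc(Cl)c4)c(C#N)c(=O)[nH]3)s2)cc1` has not yet been measured. It differs from compound 3 by chloro in place of hydrogen on an aromatic carbon. Among the measured compounds shown here, this is the same kind of change as the one from compound 1 to compound 2, but not the same: the entering chloro sits para to a large group in compound 2 and meta to a large group in compound 4, and the core is different. Because the step of a number 31.9 percentage points lower from compound 1 to compound 2 (beyond the scatter) was large, a step in the same direction is expected for compound 4, though the shift in place and core make its size uncertain, so the expected step is a number 19 percentage points lower from compound 3 to compound 4 (beyond the scatter), smaller than the measured one. For compound 4 the estimated number in this assay is 80%, with an expected range from 55% to 105%.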

Compound 4, a percentage reported as activity, at one concentration (the size of the read-out at that concentration, not a potency): 95.7%
Compound 4: middle estimate off by 15.7 percentage points, on the low side; the range from low to high includes it.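

In this assay, chloro in place of hydrogen on an aromatic carbon gives a number 3.3 percentage points lower from compound 3 to compound 4 (within the scatter), and this step does not match the earlier one: the same change on two cores in this assay, a number 31.9 percentage points lower (beyond the scatter) from compound 1 to compound 2 and a number 3.3 percentage points lower (within the scatter) from compound 3 to compound 4, 28.6 percentage points apart, beyond the scatter of two such steps So in this series, the large step seen on the core of compound 1 does not carry over in size to the core of compound 3, and a chloro gain on one core cannot be taken as a guide to the other. Among these compounds, what this does not show is the source of the gap: the two pairs differ in their core and also in where the chloro sits on the ring, and with only two pairs these cannot be told apart.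

The compounds shown leave open whether a 3-chlorophenyl group on the core of compound 1 would give a step like that of compound 2 or one like that of compound 4, and whether chloro placed as in compound 2 would give a larger step on the core of compound 3. They also leave open how other groups at this ring, such as an amine or a carboxylic acid, would behave on either core.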